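A few compounds are considered here, and "the series" means these few. Any claim that something is new, unique, unknown or untested is made for them only; others in the source may bear on it.

Compound 1 `COc1cc([C@@H]2Oc3cc(/C=C/C=O)cc(OC)c3O[C@H]2CO)cc(OC)c1O` – > 50000 nM in a functional assay on cells (Neutrophil, Homo sapiens) for inhibition; a lower number here means a stronger inhibitor, a higher number a weaker inhibitor
Compound 2 `COc1cc([C@@H]2Oc3cc(/C=C/C=O)ccc3O[C@H]2CO)cc(OC)c1O` – > 50000 nM
Compound 3 `COc1cc([C@@H]2Oc3cc(/C=C/C=O)cc(O)c3O[C@H]2CO)cc(OC)c1OC` – > 50000 nM

Each of these three values is a limit of the assay rather than a number. Compound 1 thus stands at the limit of > 50000 nM in this assay, at which 3 of the 3 values shown sit, and nothing places it more closely. Compound 4 `COc1cc([C@@H]2Oc3cc(/C=C/C=O)cc(OC)c3O[C@H]2CO)ccc1O` differs from compound 1 in one place: hydrogen in place of methoxy on an aromatic carbon. Within the data shown here, the only measured step of the same kind, a step that the two limits leave unreadable from compound 1 to compound 2, cannot be read, since both of its ends are limits. Among the measured compounds shown here, no measured step therefore sets a size or direction for this change in this assay, and compound 4 is expected to remain at the limit as well. The step from compound 1 is expected to be a step that the limit leaves unreadable from compound 1 to compound 4. Compound 4 is estimated at 60000 nM, with a range from 20000 nM to 200000 nM.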

Compound 4, half-maximal inhibitory concentration: > 50000 nM
Compound 4: no number, only a limit; the forecaster's own chance of this, stated with the estimate: 85%; the middle value is on the limit's open side.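

Compound 4, like compound 1, has only a limit of the assay as its value, so the step between them cannot be read. The compounds shown leave open what effect, if any, hydrogen in place of methoxy has in this assay, and how strongly any of them inhibits: the limit of > 50000 nM in this assay, at which 4 of the 4 values shown sit.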